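Swapping an Aryl Group in an Antiproliferative Series

The source may report more compounds than this note shows. Statements on the series, on what has been measured and on what is new or still open speak of the compounds shown alone.

Of the compounds shown here, two of this set have been tested in a functional assay on HCT-116 cells (Homo sapiens) for antiproliferative activity, read by MTT assay, with a stated time of 48 h; on this read-out lower numbers stand for stronger inhibition and higher numbers for weaker inhibition. Compound 1 `CCOc1ccccc1-n1nncc1CN1C(=O)C2(C(C#N)=C(N)Oc3c2c2nc4ccccc4nc2c2ccccc32)c2ccccc21` was the first. In this assay compound 1 gives > 50000 nM, which is a limit of the assay rather than a measured number. Among the compounds with values here, compound 2 `COc1ccc(-n2nncc2CN2C(=O)C3(C(C#N)=C(N)Oc4c(N)cc5nc6ccccc6nc5c43)c3ccccc32)cc1` differs from compound 1 in more than one place, so no single step joins the two. In this assay compound 2 gives > 50000 nM, again a limit and not a number. Compound 2 therefore stands at the weak end of everything seen so far: the limit of > 50000 nM in this assay, at which 2 of the 2 values shown sit.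

Compound 3 `N#CC1=C(N)Oc2c(N)cc3nc4ccccc4nc3c2C12C(=O)N(Cc1cnnn1-c1ccc(Cl)cc1Cl)c1ccccc12` has not yet been measured. It differs from compound 2 in a single place, namely (2,4-dichlorophenyl in place of 4-methoxyphenyl on an aromatic nitrogen). Within the data shown here, no pair of measured compounds differing in just one place exists here, so there is no measured step to lean on. Both measured compounds sit at the limit, and compound 3 would have to break that pattern to return a number. The step that the limit leaves unreadable from compound 2 to compound 3 is expected to be none beyond the usual scatter. Compound 3 is expected to give about 60000 nM, most likely between 20000 nM and 200000 nM, and most probably as a limit once more.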

Compound 3, half-maximal inhibitory concentration: > 50000 nM
Compound 3 ended at the assay's limit (the forecaster's own chance of this, stated with the estimate: 75%); the middle value is on the limit's open side.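

In this assay compound 3 gives > 50000 nM as a limit of the assay and not a number. Compound 2 also sits at a limit, so the swap from 4-methoxyphenyl to 2,4-dichlorophenyl between compound 2 and compound 3 cannot be read as a step. Whether this aryl group affects activity at all stays open: the limit of > 50000 nM in this assay, at which 3 of the 3 values shown sit.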